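The source may report more compounds than this note shows. Statements on the series, on what has been measured and on what is new or still open speak of the compounds shown alone.

Working notes on the hydrazone series. Within the data shown here, in an assay on isolated protein for inhibition of Amine oxidase [flavin-containing] A (Homo sapiens), read by fluorescence, with a stated time of 20 min (a lower number here means a stronger inhibitor, a higher number a weaker inhibitor), compound 1 `CC/C(C)=N\Nc1nc(-c2cccc([N+](=O)[O-])c2)cs1` gives 20500 nM and holds the lower of the two numbers so far, though its only neighbour, compound 2 `CCC(CC)=NNc1nc(-c2cccc([N+](=O)[O-])c2)cs1`, sits within the scatter of it: in this assay compound 2 gives 24300 nM, and the step of a 1.2-fold higher number from compound 1 to compound 2 (0.07 log units; within the scatter) is too small to read as a change. The unmeasured compound 3 `C/C(CC(C)C)=N/Nc1nc(-c2cccc([N+](=O)[O-])c2)cs1` differs from compound 1 by isopropyl in place of methyl on a saturated chain carbon bound to a carbon with a double bond to nitrogen so the variation again lies on the saturated chain that hangs from the carbon with the double bond to nitrogen, on the same shared core.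

Among the measured compounds shown here, the only measured step that bears on it is the chain enlargement from compound 1 to compound 2, which left the number essentially unchanged. For the measured compounds named here, compound 3 carries a larger enlargement at a different chain carbon, and no measured pair tests that exactly. The expectation is therefore a step of about a 1.2-fold higher number from compound 1 to compound 3 (0.09 log units; within the scatter), with the direction uncertain and most likely inside the scatter. The estimate for compound 3 in this assay is 25000 nM, with a range from 9000 nM to 70000 nM.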

Compound 3, half-maximal inhibitory concentration: 4410 nM
Beside the measured number, compound 3's estimate is 5.7-fold (0.75 log units) above it, outside the stated range (below it).
By their numbers in this assay, from the lowest: compound 3; then compounds 1 and 2 (each within the scatter of the next).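

Working notes, continued. In this assay, among these compounds, isopropyl in place of methyl on a saturated chain carbon bound to a carbon with a double bond to nitrogen gives a 4.6-fold lower number from compound 1 to compound 3 (0.67 log units; beyond the scatter) and so provides the first step beyond the scatter, whereas a 1.2-fold higher number from compound 1 to compound 2 (0.07 log units; within the scatter) had left this part of the molecule looking insensitive to change. The further step, a 5.5-fold lower number from compound 2 to compound 3 (0.74 log units; beyond the scatter), points the same way: the saturated chain does affect the number, and the isobutyl chain of compound 3 stands apart from the chains of compound 1 and compound 2, whose values lie within the scatter of each other. The data shown offer no measurement that explains this difference.

From the compounds shown here alone, it remains open whether the lower number follows the branch or the length of the chain, a question that a straight butyl chain in place of the isobutyl chain would address on the shared core. Also open, going by these compounds, is how far the trend runs, for which a longer branched chain or a cyclohexyl group at the same place would be informative.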